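Amide chain length and cytotoxicity: notes on the series

A few compounds are considered here, and "the series" means these few. Any claim that something is new, unique, unknown or untested is made for them only; others in the source may bear on it.

Measured so far:
Compound 1 `CCCCCC(=O)NCC(C)(C)CC1=C(O)C(=O)c2ccccc2C1=O` — 46600 nM
Compound 2 `CCCCCCCCCC(=O)NCC(C)(C)CC1=C(O)C(=O)c2ccccc2C1=O` — 15000 nM

In an ADME assay on Vero cells (Chlorocebus sabaeus) for cytotoxicity, read by reporter gene assay, with a stated time of 4 days (a lower number here means a stronger inhibitor, a higher number a weaker inhibitor), compound 1 gives 46600 nM and compound 2 gives 15000 nM. Among the measured compounds shown here, compound 2 holds the lowest of the two numbers; its only neighbour is compound 1, and the step of a 3.1-fold lower number from compound 1 to compound 2 (0.49 log units; beyond the scatter) separates them.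

Compound 3 `CCCCCCCCCCCCCC(=O)NCC(C)(C)CC1=C(O)C(=O)c2ccccc2C1=O` is not yet measured in this assay. It differs from compound 2 by butyl in place of hydrogen on a saturated chain carbon, nine bonds along the chain from a carbonyl carbon. For the measured compounds named here, the single measured step that bears on this change is a 3.1-fold lower number from compound 1 to compound 2 (0.49 log units; beyond the scatter), which likewise put butyl in place of hydrogen on a saturated chain carbon of the amide chain. On that basis a step of similar kind, in the same direction and of comparable or somewhat smaller size, is expected for compound 3; the expected step is a 2.5-fold lower number from compound 2 to compound 3 (0.40 log units; beyond the scatter). Compound 3 is accordingly estimated at 6000 nM, with a range from 2500 nM to 15000 nM. Going by the values given here, with only one prior step to go on, the range is kept wide, and a number rather than a limit is expected.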

Compound 3, half-maximal inhibitory concentration: 9810 nM
Compound 3: the middle estimate sits 1.6-fold (0.21 log units) below what was measured; low and high end bracket the measured number.
By their numbers in this assay, from the lowest: compounds 3 and 2 (each within the scatter of the next); then compound 1.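

In this assay, among the compounds shown here, the second butyl, placed on a saturated chain carbon nine bonds along the chain from a carbonyl carbon, gives a 1.5-fold lower number from compound 2 to compound 3 (0.18 log units; within the scatter), so at this position the same change no longer yields a step that can be told from the scatter, as the earlier butyl step at five bonds did. Compound 2 and compound 3 therefore cannot be ordered, although the full change of octyl in place of hydrogen, five bonds along the chain from a carbonyl carbon, gives a 4.8-fold lower number from compound 1 to compound 3 (0.68 log units; beyond the scatter) and remains beyond the scatter, a modest span across the three compounds. Nothing at hand bears on why the two butyl steps read differently.

The compounds shown leave open whether a longer chain than that of compound 3 would stay within the scatter of compound 3 or would separate from it in either direction. They also leave open whether an amine or a carboxylic acid at the far end of the amide chain would change the reading in this assay at a comparable chain length.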